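A Ring-Bearing Substituent Replaces the Urea on the Pyrrolidine Nitrogen

The source may hold more compounds than are shown below. What is called first, only, known or untested is meant among the compounds shown, and "the series" means these compounds.

Three compounds share a core and differ only in the group carried on the ring nitrogen. Compound 1 `C[C@@H](O[C@@H]1CN(C=O)C[C@H]1c1ccc(F)cc1)c1cc(C(F)(F)F)cc(C(F)(F)F)c1` bears a plain formyl group and in an assay on CHO cells for displacement of a labelled ligand from Substance-P receptor (Homo sapiens) (on this read-out higher numbers stand for weaker inhibition and lower numbers for stronger inhibition), gives 0.24 nM. Compound 2 `Cc1cnc(C(=O)N2C[C@@H](O[C@H](C)c3cc(C(F)(F)F)cc(C(F)(F)F)c3)[C@H](c3ccc(F)cc3)C2)cn1` carries a 5-methylpyrazin-2-yl on that carbonyl carbon and gives 0.12 nM in this assay. Compound 3 `CC(C)NC(=O)N1C[C@@H](O[C@H](C)c2cc(C(F)(F)F)cc(C(F)(F)F)c2)[C@H](c2ccc(F)cc2)C1` carries an isopropylamino there and gives 0.06 nM. Compound 3 thus holds the lowest number of the three; its step of a 4.0-fold lower number from compound 1 to compound 3 (0.60 log units; beyond the scatter) lies beyond the scatter, whereas a 2.0-fold lower number from compound 2 to compound 3 (0.30 log units; within the scatter) and a 2.0-fold lower number from compound 1 to compound 2 (0.30 log units; within the scatter) do not.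

Compound 4 `C[C@@H](O[C@@H]1CN(C2=CC(=O)OC2)C[C@H]1c1ccc(F)cc1)c1cc(C(F)(F)F)cc(C(F)(F)F)c1` goes a different way: a group of 6 heavy atoms (4 carbon, 2 oxygen; one five-membered non-aromatic ring with 1 hetero atom) in place of a group of 6 heavy atoms (4 carbon, 1 nitrogen, 1 oxygen; no ring), on an amine nitrogen in a ring. For the measured compounds named here, none of the measured steps changes the carbonyl itself or introduces a ring on the nitrogen, so no step bears directly on this change. What the three steps do show is that the substituent on this nitrogen moved the numbers only over a modest range, from compound 1 to compound 3. On that basis compound 4 is expected to stay in that range, with the estimated step of a 2.5-fold higher number from compound 3 to compound 4 (0.40 log units; beyond the scatter) counted as a loss from compound 3 that may not exceed the scatter. Compound 4 is therefore estimated at 0.15 nM, between 0.04 nM and 0.6 nM.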

Compound 4, half-maximal inhibitory concentration: 0.16 nM
For compound 4 the middle estimate is 1.1-fold (0.03 log units) below the measured one; the measured number falls inside the stated range.
By their numbers in this assay, from the lowest: compounds 3, 2, 4 and 1 (each within the scatter of the next, the first and the last beyond it).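

For the compounds shown here, compound 4 is the only compound here whose group on this ring nitrogen is not joined through a carbonyl carbon, and in this assay the exchange of isopropylcarbamoyl for this group registers beyond the scatter, though only modestly (a 2.7-fold higher number from compound 3 to compound 4 (0.43 log units; beyond the scatter)). Set against the two other carbonyl-linked groups, the same ring cannot be told apart from them (a 1.3-fold higher number from compound 2 to compound 4 (0.12 log units; within the scatter); a 1.5-fold lower number from compound 1 to compound 4 (0.18 log units; within the scatter)), so the five-membered non-aromatic ring is tolerated on this nitrogen at a level matching both the 5-methylpyrazin-2-yl carbonyl group and the plain formyl group, and only the isopropylcarbamoyl of compound 3 separates from it. Nothing shown here accounts for that one separation.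

The compounds shown leave open whether the edge of compound 3 belongs to its amide hydrogen or to its isopropyl chain, which a dimethylamino group or a longer chain on the same carbonyl carbon would separate. They also leave open how much of the ring in compound 4 is needed, as an open-chain ester or a saturated five-membered lactone on this nitrogen would show.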